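Aryl groups on the piperazine nitrogen and A2b binding

A few compounds are considered here, and "the series" means these few. Any claim that something is new, unique, unknown or untested is made for them only; others in the source may bear on it.

Compound 1 `CCCn1c(=O)[nH]c2nc(-c3ccc(S(=O)(=O)N4CCN(c5ccc(Cl)cc5F)CC4)cc3)[nH]c2c1=O`: 1.91 nM
Compound 2 `CCCn1c(=O)[nH]c2nc(-c3ccc(S(=O)(=O)N4CCN(C)CC4)cc3)[nH]c2c1=O`: 48.2 nM
Compound 3 `CCCn1c(=O)[nH]c2nc(-c3ccc(S(=O)(=O)N4CCN(c5cccc(Cl)c5)CC4)cc3)[nH]c2c1=O`: 0.342 nM

In an assay on CHO cells for displacement of a labelled ligand from adenosine receptor A2b (Homo sapiens), read by scintillation counting, with a stated time of 75 min, in the presence of a further agent that is not named here (on this read-out higher numbers stand for weaker inhibition and lower numbers for stronger inhibition), compound 3 gives the lowest of the three numbers. Its nearest neighbour is compound 1, a 5.6-fold lower number from compound 1 to compound 3 (0.75 log units; beyond the scatter), and the furthest is compound 2, a 140-fold lower number from compound 2 to compound 3 (2.15 log units; beyond the scatter). Compound 4 `CCCn1c(=O)[nH]c2nc(-c3ccc(S(=O)(=O)N4CCN(c5ccccc5Br)CC4)cc3)[nH]c2c1=O` differs from compound 3 in one place: 2-bromophenyl in place of 3-chlorophenyl on an amine nitrogen in a ring. Within the data shown here, no measured step swaps one aryl group for another bearing only a single halogen, so the expectation rests on two observations: aryl in place of methyl, a 140-fold lower number from compound 2 to compound 3 (2.15 log units; beyond the scatter), and a change of halogen pattern on the aryl, a 5.6-fold lower number from compound 1 to compound 3 (0.75 log units; beyond the scatter). Since compound 4 keeps an aryl group, a modest move toward a higher number is expected, a 2.9-fold higher number from compound 3 to compound 4 (0.47 log units; beyond the scatter). Compound 4 is therefore estimated at 1 nM, with a range from 0.3 nM to 4 nM.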

Compound 4, inhibition constant: 0.137 nM
For compound 4 the middle estimate is 7.3-fold (0.86 log units) above the measured one; the measured number lies below the stated range.
By their numbers in this assay, from the lowest: compound 4; then compound 3; then compound 1; then compound 2.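

In this assay, 2-bromophenyl in place of 3-chlorophenyl gives a 2.5-fold lower number from compound 3 to compound 4 (0.40 log units; beyond the scatter), showing that this position on the piperazine nitrogen still responds to a swap between aryl groups each bearing a single halogen. The lead of aryl over methyl widens to a 350-fold lower number from compound 2 to compound 4 (2.55 log units; beyond the scatter), and replacing 4-chloro-2-fluorophenyl gives a 14-fold lower number from compound 1 to compound 4 (1.14 log units; beyond the scatter). Nothing measured here accounts for this gain. The halogen and its place change together in this step, so the compounds shown do not separate the two. As far as these compounds go, how a methoxy group or an amine on the aryl ring would fare also remains open.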